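A few compounds are considered here, and "the series" means these few. Any claim that something is new, unique, unknown or untested is made for them only; others in the source may bear on it.

Of the compounds shown here, three built on a shared core have been tested so far in a functional assay on cells (Tumor Cell line, Homo sapiens) for cytotoxicity; on this read-out lower numbers stand for stronger inhibition of growth and higher numbers for weaker inhibition of growth. Compound 1 `Cc1cc(C)c2c(O)cc(-c3ccc(Cl)cc3)nc2n1` gives 19500 nM and compound 2 `Oc1cc(-c2ccc(Cl)cc2)nc2ncccc12` gives 38900 nM, two values that lie within the usual scatter of each other. Compound 3 `COc1ccccc1-c1cc(O)c2ccc(C)nc2n1`, which carries a different aromatic group on the core, gives 79400 nM. This is the highest of the three numbers, so compound 3 inhibits growth most weakly. Compound 2 is its nearest neighbour and compound 1 its furthest, and both gaps lie beyond the scatter.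

Compound 4 `COc1ccccc1-c1cc(O)c2cccnc2n1` differs from compound 3 in one place: hydrogen in place of methyl on an aromatic carbon. This is hydrogen in place of methyl on an aromatic carbon, next to the ring nitrogen. For the measured compounds named here, no measured pair shows this single change on its own, so the data offer only an indirect hint. Compound 1 at 19500 nM carries methyl groups that compound 2 at 38900 nM lacks, yet those two values do not separate beyond the scatter. That pair also differs in more than one place, so the hint is weak. The expected 1.1-fold higher number from compound 3 to compound 4 (0.03 log units; within the scatter) therefore stays within the scatter. The estimate for compound 4 is 85000 nM, with an expected range from 38000 nM to 190000 nM.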

Compound 4, concentration for 50% growth inhibition: 40700 nM
Compound 4: the middle estimate sits 2.1-fold (0.32 log units) above what was measured; measured number inside the range.
By their numbers in this assay, from the lowest: compounds 1, 2, 4 and 3 (each within the scatter of the next, the first and the last beyond it).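

For the compounds shown here, compounds 3 and 4 are the first pair to show this single change on its own: in this assay, hydrogen in place of methyl on an aromatic carbon, next to the ring nitrogen, gives a 2.0-fold lower number from compound 3 to compound 4 (0.29 log units; within the scatter). Ordinary variation between repeated measurements could account for a step of this size, so this pair gives no firm sign that the methyl group matters for growth inhibition at this position, and the two compounds cannot be ranked against each other. No measurement of any other kind is available here to help interpret this result.

The compounds shown leave open whether a different group on this carbon, such as an ethyl group, an amine or a carboxylic acid, would move the number beyond the scatter, since methyl and hydrogen are the only two groups compared here. Going by these compounds alone, they also leave open whether the same swap would give a similar step on a compound carrying a different aromatic group from the one that compounds 3 and 4 share.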